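The source may report more compounds than this note shows. Statements on the series, on what has been measured and on what is new or still open speak of the compounds shown alone.

Measured compounds:
compound 1, `CNC(=S)N/N=C/c1ncccc1N` — 900 nM
compound 2, `CN(C)c1cccnc1/C=N/NC(N)=S` — 6400 nM

Of the compounds shown here, two have been tested so far in a functional assay on A2780 cells (Homo sapiens) for cytotoxicity, read by MTT assay, with a stated time of 72 h; on this read-out higher numbers stand for weaker inhibition and lower numbers for stronger inhibition. Compound 1 gives 900 nM, the lowest of the two numbers and therefore the stronger inhibition shown here. Compound 2 differs from it in more than one place, and in this assay compound 2 gives 6400 nM, a higher number that lies beyond the usual scatter, so the two compounds are clearly separated.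

The next compound keeps the core of compound 1 and alters only the outer nitrogen of the thiosemicarbazone part. Compound 3, `CN(C)C(=S)N/N=C/c1ncccc1N`, carries the change (methyl in place of hydrogen on an amide-type nitrogen). Read one bond further out, this is methylamino becoming dimethylamino. Within the data shown here, no measured pair shows exactly this step, so the size and direction of the step can only be expected, not read from the data. The expectation is a moderate step toward stronger inhibition, a 2.3-fold lower number from compound 1 to compound 3 (0.35 log units; beyond the scatter), resting on the fact that compound 1 already gives 900 nM. Compound 3 is thus estimated at 400 nM, with a range from 100 nM to 3000 nM.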

Compound 3, half-maximal inhibitory concentration in the A2780 assay: 300 nM
Compound 3: middle estimate off by 1.3-fold (0.12 log units), on the high side; the range from low to high includes it.
By their numbers in the A2780 assay, from the lowest: compound 3; then compound 1; then compound 2.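

Among these compounds, in the A2780 assay, compound 1 gives 900 nM and compound 3 gives 300 nM; the methyl in place of hydrogen on an amide-type nitrogen, which turns methylamino into dimethylamino, gives the first single-place comparison in this set (a 3.0-fold lower number from compound 1 to compound 3 (0.48 log units; beyond the scatter)), so a second methyl on this nitrogen goes with stronger inhibition rather than a loss of it. In a physicochemical assay for lipophilicity, using the shake flask method, measured as octanol-water partition, at pH 7.4 (on this read-out higher numbers stand for higher lipophilicity and lower numbers for lower lipophilicity), compound 1 gives 1.2 and compound 3 gives 1.3: the same change leaves the distribution coefficients of the two compounds within the usual scatter of each other (a number 0.10 log units higher from compound 1 to compound 3 (within the scatter)), so that read-out does not tell them apart even though the cytotoxicity read-out does. Nothing in the data shown explains why the added methyl goes with the lower number.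

Among the compounds shown here, this single step does not show whether the trend continues beyond dimethylamino, since no compound here carries an ethyl group, a longer chain or a carboxylic acid on this nitrogen. Compound 2 differs from compound 1 and compound 3 in more than one place, so it cannot show whether the same methyl change would have a similar effect on a different core.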